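Benzoxazolone amides: from anilide to pyridinylmethyl amide

This account rests on a few compounds, and the source may have more. Where it says the series, first, only, none or still open, it means among the compounds named here.

This account follows compound 1 `O=C(Cn1c(=O)oc2cc([N+](=O)[O-])ccc21)Nc1ccccc1` into compound 3 `O=C(Cn1c(=O)oc2cc([N+](=O)[O-])ccc21)NCc1ccccn1`, within a small set of benzoxazolone acetamides tested in an ADME assay on RAW264.7 cells (Mus musculus) for cytotoxicity, read by MTT assay, with a stated time of 72 h, tested at 100 uM; on this read-out lower numbers stand for a weaker effect and higher numbers for a stronger effect at the one concentration tested. In this assay, among the compounds with values here, compound 1 gives 26.4%, the lowest of the two numbers measured so far. Within the data shown here, its only measured neighbour is compound 2 `O=C(Cn1c(=O)oc2ccccc21)Nc1ccccc1`, which in this assay gives 39.8%; the step of a number 13.4 percentage points higher from compound 1 to compound 2 (beyond the scatter) arises from hydrogen in place of nitro on an aromatic carbon, a change on the shared core rather than on the amide side.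

Compound 3 keeps the nitro on the core and instead alters the amide substituent: (pyridin-2-yl)methyl in place of phenyl on an amide-type nitrogen. Among the measured compounds shown here, no measured step in this set touches the amide-type nitrogen, so the only step known, from compound 1 to compound 2, does not speak to this change. With nothing in the data pointing in either direction, the expectation for the step of a number 0.6 percentage points higher from compound 1 to compound 3 (within the scatter) is that it lies within the scatter. On that basis compound 3 is estimated at 27% in this assay, with a range from 10% to 45%, and the measured number is awaited.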

Compound 3, a percentage reported as inhibition, at one concentration (the size of the read-out at that concentration, not a potency): 33.4%
Estimate against measurement, compound 3: 6.4 percentage points below; the measured number falls inside the stated range.
By their numbers in this assay, from the lowest: compounds 1, 3 and 2 (each within the scatter of the next, the first and the last beyond it).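

In this assay, within the data shown here, the first measured change on the amide-type nitrogen, (pyridin-2-yl)methyl in place of phenyl, gives a number 7 percentage points higher from compound 1 to compound 3 (within the scatter), with the nitro group kept on the shared core. Among these compounds, until now, the only measured step was on the core, a number 13.4 percentage points higher from compound 1 to compound 2 (beyond the scatter), so this result adds that, in the setting of compound 1, exchanging phenyl for (pyridin-2-yl)methyl, which brings a ring with a hetero atom and a hydrogen-bond acceptor, does not shift the read-out beyond the usual scatter. No accompanying measurement bears on why the read-out responds as it does to this exchange.

The compounds shown leave open how the (pyridin-2-yl)methyl amide behaves with hydrogen in place of nitro on the core, so it remains unknown whether the amide-side result holds once the core changes. They also do not separate the ring nitrogen from the added carbon, which a benzyl group or a directly attached pyridin-2-yl group on the amide-type nitrogen would do.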